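Swapping the methoxyphenyl of compound 1 for a chlorophenyl

This account rests on a few compounds, and the source may have more. Where it says the series, first, only, none or still open, it means among the compounds named here.

Of the compounds shown here, three sharing one core have been tested in an assay on CHO cells for displacement of a labelled ligand from adenosine receptor A3 (Homo sapiens), read by scintillation counting, tested at 1 uM; on this read-out higher numbers stand for more inhibition at the one concentration tested (going by the name of the read-out) and lower numbers for less inhibition. Compound 1 `COc1ccc(Cc2nc(N)c3nn(-c4ccccc4)cc3n2)cc1` gives 38% and stands highest of the three, ahead of compound 3 `Nc1nc(Cc2ccccc2Cl)nc2cn(-c3ccccc3)nc12`, which gives 22%, and of compound 2 `Cc1cccc(Cc2nc(N)c3nn(-c4ccccc4)cc3n2)c1`, which gives 11%. Both of those differ from compound 1 only in the ring that hangs from a saturated chain carbon bound to an aromatic carbon: a number 27 percentage points lower from compound 1 to compound 2 (beyond the scatter), and a number 16 percentage points lower from compound 1 to compound 3 (beyond the scatter), while a number 11 percentage points higher from compound 2 to compound 3 (beyond the scatter).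

Compound 4 `Nc1nc(Cc2cccc(Cl)c2)nc2cn(-c3ccccc3)nc12` is not yet measured. It differs from compound 1 in the same place: 3-chlorophenyl in place of 4-methoxyphenyl on a saturated chain carbon bound to an aromatic carbon. The two measured steps that bear on this, both away from 4-methoxyphenyl toward a ring carrying a single small group, each went down. A drop of comparable size is therefore expected in this assay for compound 4, namely a number 20 percentage points lower from compound 1 to compound 4 (beyond the scatter). On that basis compound 4 is estimated to give about 18%, with a likely range from 5% to 34%.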

Compound 4, a percentage reported as inhibition, at one concentration (the size of the read-out at that concentration, not a potency): 42%
For compound 4 the middle estimate is 24 percentage points below the measured one, and the stated range ends below it.
By their numbers in this assay, from the lowest: compound 2; then compound 3; then compounds 1 and 4 (each within the scatter of the next).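

In this assay the ring on the saturated chain carbon need not be 4-methoxyphenyl to keep the read-out: with 3-chlorophenyl there is a number 4 percentage points higher from compound 1 to compound 4 (within the scatter) and no real difference. For the compounds shown here, the identity and the place of the single group on that ring both count, since chloro in place of methyl gives a number 31 percentage points higher from compound 2 to compound 4 (beyond the scatter) and moving from 2-chlorophenyl to 3-chlorophenyl gives a number 20 percentage points higher from compound 3 to compound 4 (beyond the scatter) so the earlier falls do not apply to every ring carrying one small group. Nothing available explains these differences.

Still open, from the compounds shown here alone, is how 4-chlorophenyl or 3-methoxyphenyl would compare, which would separate the effect of the group from that of its place on the ring. Also open, going by these compounds, is whether an amine or a carboxylic acid on the ring, or a longer chain in place of the saturated chain carbon, would keep this level of inhibition.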